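A few compounds are considered here, and "the series" means these few. Any claim that something is new, unique, unknown or untested is made for them only; others in the source may bear on it.

Three compounds share one core and differ only in the group attached to the five-membered ring. Compound 1 `O=C1NC(=O)/C(=C/c2ccc(OCCSc3nnc(-c4ccccc4)[nH]3)cc2)S1`, compound 2 `O=C1NC(=O)/C(=C/c2ccc(OCCSc3nnc(-c4ccccc4)o3)cc2)S1` and compound 3 `O=C1NC(=O)/C(=C/c2ccc(OCCSc3nnc(Cc4ccccc4)o3)cc2)S1` were tested in a functional assay on the whole organism (strain Wistar) with Rattus norvegicus as the target, with a stated time of 15 days, at a dose of 3 mg/kg by the oral route (on this read-out higher numbers stand for a stronger effect at the one dose given and lower numbers for a weaker effect), where compound 1 gives 18.6%, compound 2 gives 21.6% and compound 3 gives 18.5%. The number for compound 3 is the lowest of the three shown, yet its gaps to the other two lie within the scatter. Going by the values given here, the one step between direct neighbours, a number 3.1 percentage points lower from compound 2 to compound 3 (within the scatter), moved nothing beyond the scatter. Compound 4 `O=C1NC(=O)/C(=C/c2ccc(OCCSc3nnc(-c4cccnc4)o3)cc2)S1` differs from compound 3 by pyridin-3-yl in place of benzyl on an aromatic carbon. Among the compounds with values here, no measured step brings in a ring with a hetero atom, so the expectation rests only on the small movements seen so far. Compound 4 is therefore expected to give about 20% in this assay, between 10% and 32%, an estimated step of a number 1.5 percentage points higher from compound 3 to compound 4 (within the scatter).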

Compound 4, a percentage reported as activity, at one dose (the size of the read-out at that dose, not a potency): 40.7%
Compound 4: middle estimate off by 20.7 percentage points, on the low side; measured number above the stated range.
By their numbers in this assay, from the lowest: compounds 3, 1 and 2 (each within the scatter of the next); then compound 4.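

In this assay, the group on this carbon of the five-membered ring can move the read-out after all: pyridin-3-yl in place of benzyl gives a number 22.2 percentage points higher from compound 3 to compound 4 (beyond the scatter), and pyridin-3-yl in place of phenyl gives a number 19.1 percentage points higher from compound 2 to compound 4 (beyond the scatter). The step from phenyl to benzyl stayed within the scatter, so the larger change appears only with the ring that carries a nitrogen.

Going by these compounds, what a pyridin-4-yl or a simple amine on this carbon would give remains open. Nothing available explains the rise.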